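Swapping methyl for isopropyl at the ring amine

A few compounds are considered here, and "the series" means these few. Any claim that something is new, unique, unknown or untested is made for them only; others in the source may bear on it.

compound 1 `O=C1NCCc2nc(C#Cc3cccc(F)c3)sc21`: > 10000 nM
compound 2 `CCN1CCc2nc(C#Cc3ccccc3)sc2C1`: 1200 nM

In an assay on HEK293 cells for negative allosteric modulation of metabotropic glutamate receptor 5 (Homo sapiens), read by FLIPR, with a stated time of 1 h (a higher number here means a weaker inhibitor, a lower number a stronger inhibitor), compound 2 gives 1200 nM, the only real number shown here. Compound 1 reports > 10000 nM, which is a limit of this assay rather than a number (the limit of > 10000 nM in this assay, at which 1 of the 2 values shown sits). Compound 3 `CC(C)CN1CCc2nc(C#Cc3ccccc3)sc2C1` is compound 2 with isopropyl in place of methyl on a saturated chain carbon bound to an amine nitrogen in a ring. Among the compounds with values here, no measured pair differing in one place is available, so this change is judged on its own. The expected step in this assay is small, a mild weakening at most, close to the scatter. Compound 3 is estimated at 1600 nM, within 500 nM to 5000 nM. The estimated step of a 1.3-fold higher number from compound 2 to compound 3 (0.12 log units; within the scatter) stays near the scatter.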

Compound 3, half-maximal inhibitory concentration: 650 nM
For compound 3 the middle estimate is 2.5-fold (0.39 log units) above the measured one, and the stated range covers the measured number.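

Within the data shown here, this is the first step that can be read at this place, on a saturated chain carbon bound to an amine nitrogen in a ring: in this assay, isopropyl in place of methyl gives a 1.8-fold lower number from compound 2 to compound 3 (0.27 log units; within the scatter). Methyl and isopropyl therefore cannot be told apart here, and the place accepts the branched group without a measurable loss. Nothing measured here gives a reason for this step.

On these data alone, whether a longer chain, a hydroxyl group or an amine at this place would move the number beyond the scatter stays open. The compounds shown compare only these two groups here, so no trend with group size can be drawn.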